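Thiosemicarbazone series on prostate carcinoma cells: methoxy versus chloro

This account rests on a few compounds, and the source may have more. Where it says the series, first, only, none or still open, it means among the compounds named here.

Measured so far:
compound 1 `CC1=CC[C@H](C(C)(C)N=C=S)CC1` — > 100000 nM
compound 2 `CC1=CC[C@H](C(C)(C)NC(=S)N/N=C/c2ccccc2)CC1` — 1300 nM
compound 3 `COc1ccc(/C=N/NC(=S)NC(C)(C)[C@H]2CC=C(C)CC2)cc1` — < 40 nM

In a functional assay on PC-3 cells (Homo sapiens) for inhibition, read by sulforhodamine B assay, with a stated time of 48 h (a higher number here means a weaker inhibitor of growth, a lower number a stronger inhibitor of growth), compound 1 gives > 100000 nM, which is a limit of the assay and not a number. Compound 2 gives 1300 nM in this assay. Compound 3 sits at < 40 nM in this assay, again a limit rather than a number, so its position is known only as being at or past that edge (the limit of < 40 nM in this assay, at which 1 of the 3 values shown sits). Among the measured compounds shown here, the one measured step that bears on the next compound is an at least 32-fold lower number from compound 2 to compound 3 (1.51 log units; beyond the scatter).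

Compound 4 `CC1=CC[C@H](C(C)(C)NC(=S)N/N=C/c2ccccc2Cl)CC1` differs from compound 3 by 2-chlorophenyl in place of 4-methoxyphenyl on a carbon with a double bond to nitrogen. The methoxy that carried the large gain is therefore gone, and a chlorine on a different carbon of the ring takes its place; nothing measured speaks to chlorine in this position. With the methoxy removed, the expectation for compound 4 falls back toward the level of compound 2 at 1300 nM, leaving an expected step of an at least 10-fold higher number from compound 3 to compound 4 (1.00 log units; beyond the scatter). Compound 4 is thus estimated at 400 nM, with a range from 60 nM to 2500 nM.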

Compound 4, concentration for 50% growth inhibition: 50 nM
Estimate against measurement, compound 4: 8.0-fold (0.90 log units) above, and the stated range ends above it.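

In this assay, the large gain on the phenyl ring is not unique to methoxy: chloro in place of hydrogen on an aromatic carbon gives a 26-fold lower number from compound 2 to compound 4 (1.41 log units; beyond the scatter). Exchanging 4-methoxyphenyl for 2-chlorophenyl on the carbon with a double bond to nitrogen gives an at least 1.2-fold higher number from compound 3 to compound 4 (0.09 log units; that floor lies within the scatter), so this pair does not set the two groups in order. Compound 3 stands at a limit, not a number: the limit of < 40 nM in this assay, at which 1 of the 4 values shown sits.

Open, on these data alone, is whether the gain depends on which ring carbon holds the chlorine, since only 2-chlorophenyl appears. Also open, as far as these compounds go, is how far it extends to other groups on the ring, such as an amine, a hydroxyl or a carboxylic acid.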